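Moving a Methoxy Group on the Sulfonamide Nitrogen's Ring

The compounds below may be only part of what the source reports. "The series", "measured", "known", "first", "only" and "open" are said of these compounds alone.

- Compound 1 `Cc1ccc(C)c(NS(=O)(=O)c2ccc(N3CCNC3=O)cc2)c1`: 27 nM
- Compound 2 `COc1ccc(NS(=O)(=O)c2ccc(N3CCNC3=O)cc2)cc1`: 580 nM

In a functional assay on M21 cells (Homo sapiens) for antiproliferative activity, read by sulforhodamine B assay, with a stated time of 48 h (on this read-out lower numbers stand for stronger inhibition and higher numbers for weaker inhibition), compound 2 holds the higher of the two numbers. Compound 3 `COc1cccc(NS(=O)(=O)c2ccc(N3CCNC3=O)cc2)c1` has 3-methoxyphenyl in place of 4-methoxyphenyl on a sulfonamide nitrogen. Within the data shown here, one measured step bears on this: a 21-fold higher number from compound 1 to compound 2 (1.33 log units; beyond the scatter). Among the measured compounds shown here, that large step changed the group on the same nitrogen, but no measured step moves the methoxy group alone. A moderate shift is therefore expected in this assay, towards a lower number, and it may stay within the scatter. The expected step is a 1.7-fold lower number from compound 2 to compound 3 (0.22 log units; within the scatter). Compound 3 is estimated at 350 nM, with an expected range of 90 nM to 1300 nM.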

Compound 3, half-maximal inhibitory concentration: 65 nM
Estimate against measurement, compound 3: 5.4-fold (0.73 log units) above; measured number outside the range, below it.
By their numbers in this assay, from the lowest: compound 1; then compound 3; then compound 2.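

In this assay moving the methoxy group alone gives an 8.9-fold lower number from compound 2 to compound 3 (0.95 log units; beyond the scatter) and shows that, on this sulfonamide nitrogen, the placing of one group on the ring changes the number even though no atoms are gained or lost. The comparison with the 2,5-dimethylphenyl group gives a 2.4-fold higher number from compound 1 to compound 3 (0.38 log units; beyond the scatter) and shows that 3-methoxyphenyl recovers much, but not all, of the gap seen with 4-methoxyphenyl. Nothing available explains the effect of this move. On these data alone, whether an amine or a carboxylic acid on this ring would keep such a low number remains open, as does the effect of a longer chain in place of the methoxy group.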